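Moving the Pyrazole Attachment Point in Compound 3

This account rests on a few compounds, and the source may have more. Where it says the series, first, only, none or still open, it means among the compounds named here.

In an ADME assay on MDCK-II cells (Canis lupus familiaris) for permeability (a higher number here means that the compound crosses the layer faster, a lower number that the compound crosses the layer more slowly), compound 1 `Cn1ccc(-c2cn3nccc3c(-c3cnn([C@]4(CC#N)C[C@@H](C#N)C4)c3)n2)n1` gives 20 10^-6 cm/s and compound 2 `N#CC[C@]1(n2cc(-c3nc(-c4cn[nH]c4)cn4nccc34)cn2)C[C@H](C#N)C1` gives 7 10^-6 cm/s as the lower of the two numbers. Compound 3 `N#CC[C@]1(n2cc(-c3nc(-c4cc[nH]n4)cn4nccc34)cn2)C[C@H](C#N)C1` differs from compound 2 in one place: 1H-pyrazol-3-yl in place of 1H-pyrazol-4-yl on an aromatic carbon on the same aromatic carbon of the shared core. Among the measured compounds shown here, the only measured step bearing on this is a 2.9-fold lower number from compound 1 to compound 2 (0.46 log units; beyond the scatter) in a modest change that put 1H-pyrazol-4-yl in place of 1-methyl-1H-pyrazol-3-yl. That step also removed a methyl, so it is only a loose guide. The expected change is a 1.4-fold higher number from compound 2 to compound 3 (0.15 log units; within the scatter) and stays within the scatter of such measurements. Compound 3 is estimated at 10 10^-6 cm/s with an expected range of 5 10^-6 cm/s to 20 10^-6 cm/s as the likely span.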

Compound 3, apparent permeability: 17 10^-6 cm/s
Compound 3: the middle estimate sits 1.7-fold (0.23 log units) below what was measured; the measured number falls inside the stated range.
By their numbers in this assay, from the lowest: compound 2; then compounds 3 and 1 (each within the scatter of the next).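

Joining the same pyrazole through a different ring atom, with no atoms added or lost, gives a 2.4-fold higher number from compound 2 to compound 3 (0.39 log units; beyond the scatter) in this assay, so the attachment point alone can shift the number at this position. Hydrogen in place of methyl on the aromatic nitrogen gives only a 1.2-fold lower number from compound 1 to compound 3 (0.07 log units; within the scatter) and so leaves no readable difference between compound 1 and compound 3. The earlier step from compound 1 to compound 2 changed both features at once and could not separate them.

From the compounds shown here alone, how a triazole or an amine on this aromatic carbon would compare remains open. No measurement at hand explains the shift.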